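Working notes: from compound 3 to compound 4

A few compounds are considered here, and "the series" means these few. Any claim that something is new, unique, unknown or untested is made for them only; others in the source may bear on it.

Among the measured compounds shown here, in a functional assay on MCF7 cells (Homo sapiens) for cytotoxicity, read by CellTiter-Glo, with a stated time of 5 days (on this read-out higher numbers stand for weaker inhibition and lower numbers for stronger inhibition), compound 3 `CC/C(=C(/c1ccc(/C=C/C(=O)O)cc1)c1ccc2[nH]ncc2c1)c1ccccc1S(C)(=O)=O` gives 70 nM, the highest number of the three measured so far. Compound 1 `CC/C(=C(/c1ccc(/C=C/C(=O)O)cc1)c1ccc2[nH]ncc2c1)c1ccc(Cl)cc1` gives 15 nM, and compound 2 `CC/C(=C(/c1ccc(/C=C/C(=O)O)cc1)c1ccc2[nH]ncc2c1)c1ccccc1C` gives 4 nM.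

Compound 4 `CC/C(=C(/c1ccc(/C=C/C(=O)O)cc1)c1ccc2[nH]ncc2c1)c1ccc(C#N)cc1C` has not yet been measured. Its difference from compound 3 is 4-cyano-2-methylphenyl in place of 2-(methylsulfonyl)phenyl on a double-bonded chain carbon bound to a double-bonded chain carbon and a saturated chain carbon.

The most relevant evidence is the large step of an 18-fold higher number from compound 2 to compound 3 (1.24 log units; beyond the scatter), with methylsulfonyl in place of methyl on an aromatic carbon. Compound 4 undoes that exchange, since it carries a methyl group again. The two modest steps of a 3.8-fold lower number from compound 1 to compound 2 (0.57 log units; beyond the scatter) and a 4.7-fold higher number from compound 1 to compound 3 (0.67 log units; beyond the scatter) place the 4-chlorophenyl compound between the other two. For the measured compounds named here, no measured compound carries a nitrile, and none combines two groups on this phenyl ring, so the effect of the added nitrile remains open. A large step to a lower number is expected, probably somewhat short of the full size of the step back from compound 3 to the level of compound 2.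

The expected change is a 12-fold lower number from compound 3 to compound 4 (1.07 log units; beyond the scatter). For compound 4 the estimated value is 6 nM, with an expected range of 2 nM to 20 nM.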

Compound 4, half-maximal inhibitory concentration: 5 nM
Compound 4: the middle estimate sits 1.2-fold (0.08 log units) above what was measured, within the range that was stated.
By their numbers in this assay, from the lowest: compounds 2 and 4 (each within the scatter of the next); then compound 1; then compound 3.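

In this assay, the nitrile adds nothing that can be read on the 2-methylphenyl group: a 1.3-fold higher number from compound 2 to compound 4 (0.10 log units; within the scatter), so compound 2 and compound 4 cannot be told apart, and a second group on this phenyl ring is compatible with a low number. The exchange at the double-bonded chain carbon gives a 14-fold lower number from compound 3 to compound 4 (1.15 log units; beyond the scatter), which shows that the large loss seen with 2-(methylsulfonyl)phenyl is recovered by a group that keeps the methyl and also carries a nitrile. Against the 4-chlorophenyl group the result is a 3.0-fold lower number from compound 1 to compound 4 (0.48 log units; beyond the scatter), so among these compounds the two that carry the methyl, compound 2 and compound 4, both give lower numbers than compound 1, with no listed compound going against this. Nothing shown gives a measured reason for any of these steps.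

Among the compounds shown here, it stays open whether the nitrile would give a similar number on a phenyl ring without the methyl, since the 4-chlorophenyl of compound 1 is the only group here with no methyl or methylsulfonyl. As far as these compounds go, it is also open whether an amine or a methoxy group in place of the nitrile of compound 4 would keep the number at this level.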